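The compounds below may be only part of what the source reports. "The series", "measured", "known", "first", "only" and "open" are said of these compounds alone.

Measured so far:
- compound 1, `CN1CCN(c2nc(-c3cccc(O)c3)nc3c2ncn3C)CC1`: 47.8%
- compound 2, `CN1CCN(c2nc(-c3cccc(Cl)c3)nc3[nH]cnc23)CC1`: 29.9%
- compound 3, `CN1CCN(c2nc(-c3cc(Cl)ccc3Cl)nc3[nH]cnc23)CC1`: 13%

In an assay on cells for displacement of a labelled ligand from adenosine receptor A2b (Homo sapiens), read by scintillation counting and radioligand binding, with a stated time of 30 min, tested at 10 uM (on this read-out lower numbers stand for less inhibition and higher numbers for more inhibition at the one concentration tested (going by the name of the read-out)), compound 3 gives 13%, the lowest of the three numbers. Its nearest neighbour is compound 2, with 29.9%, and the furthest is compound 1, with 47.8%; both gaps lie beyond the scatter.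

Compound 4, `CN1CCN(c2nc(-c3cccc(O)c3)nc3[nH]cnc23)CC1`, is not yet measured. It differs from compound 3 as follows: 3-hydroxyphenyl in place of 2,5-dichlorophenyl on an aromatic carbon. The 3-hydroxyphenyl group enters on the shared core at the aromatic carbon between two ring nitrogen atoms.

Within the data shown here, one measured step bears on this change. The step of a number 16.9 percentage points lower from compound 2 to compound 3 (beyond the scatter) shows that a second chloro on the phenyl ring lowered the number; removing both chloro groups and placing a hydroxy instead reverses and extends that step. Compound 1 carries the same 3-hydroxyphenyl group on a methylated core and gives 47.8%. Compound 2 shares the unmethylated core of compound 4; on that core, compound 2 gives 29.9%. These two values bracket the region where compound 4 is expected to fall, so a rise beyond the scatter is expected in this assay.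

The estimate for compound 4 is 40%, within 22% to 58%, meaning an expected step of a number 27 percentage points higher from compound 3 to compound 4 (beyond the scatter).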

Compound 4, a percentage reported as inhibition, at one concentration (the size of the read-out at that concentration, not a potency): 27%
Beside the measured number, compound 4's estimate is 13 percentage points above it; low and high end bracket the measured number.
By their numbers in this assay, from the lowest: compound 3; then compounds 4 and 2 (each within the scatter of the next); then compound 1.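

In this assay, changing the group on the aromatic carbon between two ring nitrogen atoms from 2,5-dichlorophenyl to 3-hydroxyphenyl gives a number 14 percentage points higher from compound 3 to compound 4 (beyond the scatter), so the low number of compound 3 is not shared by this hydroxylated analogue on the same core. On the phenyl ring itself, hydroxy in place of chloro gives a number 2.9 percentage points lower from compound 2 to compound 4 (within the scatter), which means that this assay does not separate the two single substituents on this core. With 3-hydroxyphenyl held constant, hydrogen in place of methyl on an aromatic nitrogen gives a number 20.8 percentage points lower from compound 1 to compound 4 (beyond the scatter), so the number of compound 1 goes with that methyl group and not with the hydroxy group alone, and no measurement at hand gives a reason for any of these steps.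

The compounds shown leave open whether the methyl step carries over to the chloro-substituted phenyl compounds, since only the 3-hydroxyphenyl pair tests it. They also leave open how a methoxy group, an amine or a carboxylic acid in place of the hydroxy on the phenyl ring would read at this single concentration.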